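Swapping the piperazine aryl for a fluorobenzyl group

The source may report more compounds than this note shows. Statements on the series, on what has been measured and on what is new or still open speak of the compounds shown alone.

Measured so far in a functional assay on MCF7 cells (Homo sapiens) for antiproliferative activity, read by sulforhodamine B assay, with a stated time of 72 h; a higher number here means a weaker inhibitor, a lower number a stronger inhibitor:
compound 1 `Cc1cccc(COc2ccc(-c3cc(CN4CCN(Cc5ccc(C(F)(F)F)cc5)CC4)no3)cc2)c1` gives 4000 nM;
compound 2 `Fc1ccc(COc2ccc(-c3cc(CN4CCN(Cc5ccc(C(F)(F)F)cc5)CC4)no3)cc2)cc1` gives 7900 nM;
compound 3 `N#Cc1cccc(COc2ccc(-c3cc(CN4CCN(c5ccc(C(F)(F)F)cc5)CC4)no3)cc2)c1` gives 2000 nM.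

Compound 3 holds the lowest of the three numbers in this assay; compound 1 sits within the scatter of it, while compound 2 lies beyond it. Within the data shown here, the only single-site step seen so far, a 2.0-fold higher number from compound 1 to compound 2 (0.30 log units; within the scatter), concerns the benzyl ether end and not the amine nitrogen in the ring. Compound 4 `N#Cc1cccc(COc2ccc(-c3cc(CN4CCN(Cc5cccc(F)c5)CC4)no3)cc2)c1` differs from compound 3 by 3-fluorobenzyl in place of 4-(trifluoromethyl)phenyl on an amine nitrogen in a ring. Among the measured compounds shown here, no measured step touches that position, so the expectation rests on compound 3 alone; a modest shift toward a higher number is expected, a 1.5-fold higher number from compound 3 to compound 4 (0.18 log units; within the scatter), within or just beyond the scatter. Compound 4 is therefore estimated at 3000 nM, ranging from 1000 nM to 9000 nM.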

Compound 4, half-maximal inhibitory concentration: 2400 nM
Compound 4: the middle estimate sits 1.3-fold (0.10 log units) above what was measured, within the range that was stated.
By their numbers in this assay, from the lowest: compounds 3, 4, 1 and 2 (each within the scatter of the next, the first and the last beyond it).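

In this assay, among these compounds, the first reading at this position shows a 1.2-fold higher number from compound 3 to compound 4 (0.08 log units; within the scatter) when 3-fluorobenzyl replaces 4-(trifluoromethyl)phenyl on the amine nitrogen in the ring. In this one pair, with the rest of the molecule held fixed, exchanging a group of 10 heavy atoms for one of 8 stays within the scatter. Nothing measured here explains why these two groups read alike.

From the compounds shown here alone, whether a phenethyl or pyridylmethyl group on that nitrogen would also stay within the scatter remains open. So does whether a carboxylic acid or an amine there would do so.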